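Working notes: from 4-nitrophenyl to 3-nitrophenyl

A few compounds are considered here, and "the series" means these few. Any claim that something is new, unique, unknown or untested is made for them only; others in the source may bear on it.

In an ADME assay on HEK-293T cells (Homo sapiens) for cytotoxicity, read by MTT assay, with a stated time of 3 days (a lower number here means that less compound is tolerated, a higher number that more compound is tolerated), compound 1 (`CC(C)(C)N(CCCc1ccccc1)C(=O)COC(=O)c1ccc([N+](=O)[O-])o1`) is reported as "not active" (no number reported), with no number given. Compound 2 (`CC(C)(C)N(Cc1ccc([N+](=O)[O-])cc1)C(=O)COC(=O)c1ccc([N+](=O)[O-])o1`) gives > 100000 nM, which is a limit of the assay and not a number. Compound 3 (`CC(C)(C)N(Cc1cccc([N+](=O)[O-])c1)C(=O)COC(=O)c1ccc([N+](=O)[O-])o1`) differs from compound 2 by 3-nitrophenyl in place of 4-nitrophenyl on a saturated chain carbon bound to an amide-type nitrogen. The expectation rests on compound 2 at > 100000 nM, again a limit. The expected change in this assay, a number no higher from compound 2 to compound 3 (the limit leaves the size open), stays within the scatter, and a report of only a limit is likely. For compound 3 the estimated value is 100000 nM, with an expected range from 40000 nM to 250000 nM.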

Compound 3, half-maximal cytotoxic concentration: 78000 nM
Estimate against measurement, compound 3: 1.3-fold (0.11 log units) above; the range from low to high includes it.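

In this assay, 3-nitrophenyl in place of 4-nitrophenyl on a saturated chain carbon bound to an amide-type nitrogen gives an at least 1.2-fold lower number from compound 2 to compound 3 (0.10 log units; that floor lies within the scatter). Compound 3 holds the only single number among the compounds shown, so this position now has one measured value rather than only a limit and a report without a number. Only a floor can be read for this step, and its true size stays open: the limit of > 100000 nM in this assay, at which 1 of the 3 values shown sits.

Going by these compounds, whether an amine or a carboxylic acid in place of the nitro group on this phenyl ring would give a step beyond the scatter remains open.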